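The compounds below may be only part of what the source reports. "The series", "measured", "known", "first", "only" and "open" are said of these compounds alone.

Compound 1 `CC(C)Oc1cncc(C2=CC3CNCC(C2)C3)c1` is a pyridine carrying an isopropoxy group on the aromatic ring and a bicyclic amine core; in an in vitro assay on SH-EP1 cells for displacement of a labelled ligand from Neuronal acetylcholine receptor; alpha4/beta2 (Homo sapiens) (a higher number here means a weaker inhibitor, a lower number a stronger inhibitor), compound 1 gives 0.26 nM, the second highest of the three numbers. Its companions are compound 2 `C1=C(c2cccnc2)CC2CNCC1C2`, which gives 0.2 nM, and compound 3 `Clc1cncc(C2=CC3CNCC(C2)C3)c1`, which gives 0.4 nM. The steps of a 1.3-fold lower number from compound 1 to compound 2 (0.11 log units; within the scatter) and a 1.5-fold higher number from compound 1 to compound 3 (0.19 log units; within the scatter) both lie within the scatter, as does a 2.0-fold higher number from compound 2 to compound 3 (0.30 log units; within the scatter), so the substituent on the aromatic carbon has so far made no difference that can be trusted. Compound 4 `C1=C(c2cncc(OCc3ccccc3)c2)CC2CNCC1C2` differs from compound 1 by benzyl in place of isopropyl on an oxygen on an aromatic ring. Among the measured compounds shown here, no measured step alters the group on that oxygen, so compound 4 is expected to give 0.4 nM, between 0.1 nM and 1.6 nM, a step of a 1.5-fold higher number from compound 1 to compound 4 (0.19 log units; within the scatter) expected to stay within the scatter.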

Compound 4, inhibition constant: 0.7 nM
Beside the measured number, compound 4's estimate is 1.8-fold (0.24 log units) below it; the measured number falls inside the stated range.
By their numbers in this assay, from the lowest: compounds 2, 1, 3 and 4 (each within the scatter of the next, the first and the last beyond it).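

Putting benzyl in place of isopropyl on an oxygen on an aromatic ring gives a 2.7-fold higher number from compound 1 to compound 4 (0.43 log units; beyond the scatter) in this assay. This is the only step among these compounds printed as beyond the scatter, so the group on that oxygen can move the number, if modestly. No measurement shown explains this shift.

Going by these compounds, whether the shift follows the larger group or the aromatic ring it brings remains open. A longer chain on that oxygen, or an amine or a carboxylic acid carried there, would extend the comparison.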